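The compounds below may be only part of what the source reports. "The series", "measured", "known", "first", "only" and "open" are said of these compounds alone.

Measured so far:
Compound 1, `COc1cc(F)ccc1-c1ccnc2[nH]c(C3CCN(CC(=O)N(C)C)CC3)cc12`: 8
Compound 2, `CC(C)n1cc(-c2ccnc3[nH]c(C4CCN(CC(=O)N5CCCC5)CC4)cc23)ccc1=O`: 7.8
Compound 3, `COc1cc(C(=O)N2CCCC2)ccc1-c1ccnc2[nH]c(C3CCNCC3)cc12`: 10.2

In a physicochemical assay for acid dissociation, compound 2 gives 7.8. Compound 1 gives 8, a number within the scatter of compound 2, so the two cannot be told apart. Compound 3 gives 10.2, a number well beyond the scatter above compound 2, and it is the highest of the three.

Compound 4, `CC(C)n1cc(-c2ccnc3[nH]c(C4CCN(Cc5cccs5)CC4)cc23)ccc1=O`, is not yet measured. It differs from compound 2 in one place: thiophen-2-yl in place of (pyrrolidin-1-yl)carbonyl on a saturated chain carbon bound to an amine nitrogen in a ring. For the measured compounds named here, no step between measured compounds matches this change. Given that compound 3 gives 10.2, compound 4 is expected to move upward from compound 2 by a number 1.00 log units higher from compound 2 to compound 4 (beyond the scatter). Compound 4 is therefore estimated at 8.8, between 8.2 and 9.4.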

Compound 4, acid dissociation constant: 6.5
Beside the measured number, compound 4's estimate is 2.30 log units above it; measured number outside the range, below it.
By their numbers in this assay, from the lowest: compound 4; then compounds 2 and 1 (each within the scatter of the next); then compound 3.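

Placing thiophen-2-yl in place of (pyrrolidin-1-yl)carbonyl on a saturated chain carbon bound to an amine nitrogen in a ring moves this assay by a number 1.30 log units lower from compound 2 to compound 4 (beyond the scatter) on an otherwise unchanged structure. For the compounds shown here, this is the first reading of a single change at this position, and it shows that the number there depends strongly on the group carried and can fall well under that of the amide. Nothing shown accounts for the direction or size of this step.

As far as these compounds go, it remains open where a morpholine amide or a plain phenyl group on that carbon would fall in this assay and how a longer chain would read. From the compounds shown here alone, whether the same change gives a step of like size on the core of compound 1 is also open.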